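The source may hold more compounds than are shown below. What is called first, only, known or untested is meant among the compounds shown, and "the series" means these compounds.

Of the compounds shown here, two of a shared dihydropyridine-type core have been measured in an assay on isolated protein for antagonist activity at Voltage-dependent L-type calcium channel subunit alpha-1C (Cavia porcellus), with a stated time of 15 min; a higher number here means a weaker inhibitor, a lower number a stronger inhibitor. Compound 1 `CC1=C(C(=O)OC2CCCC2)C(c2csc(-c3ccc(Cl)cc3)n2)C(C(=O)OC2CCCC2)=C(C)N1` carries a cyclopentyl ester on each side of the core, and in this assay compound 1 gives 19000 nM. Compound 2 `CC1=C(C(=O)OC(C)c2ccccc2)C(c2csc(-c3ccc(Cl)cc3)n2)C(C(=O)OC(C)c2ccccc2)=C(C)N1` carries a 1-phenylethyl ester on each side instead, and in this assay compound 2 gives 400000 nM. Compound 1 therefore stands at the lower, stronger end of the two numbers, with compound 2 far weaker and the gap well beyond the ordinary scatter of this kind of measurement.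

Compound 3 `COC(=O)C1=C(C)NC(C)=C(C(=O)OC2CCCC2)C1c1csc(-c2ccc(Cl)cc2)n1` keeps one cyclopentyl ester and changes the other: methyl in place of cyclopentyl on an oxygen next to a carbonyl group. Among the measured compounds shown here, with only two measured compounds, there is no directly comparable pair of measured esters to lean on. As far as these compounds go, what the two numbers do show is that changing both esters can move the result a long way, while a change on one side only is untested here. A modest step toward a lower number is expected, since the smaller ester removes part of what compound 2 has more of, but it is expected to stay within or just beyond the scatter, a 1.6-fold lower number from compound 1 to compound 3 (0.20 log units; within the scatter). Compound 3 is therefore estimated at 12000 nM, with a plausible range from 3000 nM to 50000 nM.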

Compound 3, half-maximal inhibitory concentration: 7290 nM
The estimate for compound 3 lay 1.6-fold (0.22 log units) above the measured number; the measured number falls inside the stated range.
By their numbers in this assay, from the lowest: compound 3; then compound 1; then compound 2.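

Putting methyl in place of cyclopentyl on an oxygen next to a carbonyl group, on one side of the shared core only, gives a 2.6-fold lower number from compound 1 to compound 3 (0.42 log units; beyond the scatter) in this assay, a modest step but one beyond the usual scatter. Among the compounds shown here, this is the first reading of a change at a single ester: the other cyclopentyl ester stays as it is, so the step belongs to this one position, and a group of a single carbon there does not cost activity compared with the five-carbon ring. Nothing available explains why the number falls with this change.

The compounds shown leave open how the number changes for groups of intermediate size at this oxygen, such as ethyl or isopropyl, and whether a longer chain or one ending in an amine would lower it further or raise it again. They also leave open whether a methyl ester on the other side, in place of the cyclopentyl ester that compound 3 keeps, would bring a further step in the same direction.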